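A few compounds are considered here, and "the series" means these few. Any claim that something is new, unique, unknown or untested is made for them only; others in the source may bear on it.

Compound 1, whose structure is `O=c1[nH]c(=O)n([C@H]2C[C@H](O)[C@@H](CO)O2)cc1C#CCCCCCCCCCBr`, is the reference point in a functional assay for cytotoxicity, read by microscopy (on this read-out higher numbers stand for lower toxicity in this test and lower numbers for higher toxicity in this test), where compound 1 gives 50000 nM. Compound 2, with the structure `O=c1[nH]c(=O)n([C@H]2C[C@H](O)[C@@H](CO)O2)cc1C#CCCCCCCCCCI`, differs from it by iodo in place of bromo on a saturated chain carbon, nine bonds along the chain from a triple-bonded carbon. For compound 2 in this assay only a limit is recorded, > 50000 nM. The step of a number no lower from compound 1 to compound 2 (the limit leaves the size open) therefore has no readable size because the limit of > 50000 nM in this assay, at which 1 of the 3 values shown sits, caps what the assay could report.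

Compound 3, built on a different core, has the structure `O=c1nc2oc(CCCCCCCCCBr)cc2cn1[C@H]1C[C@H](O)[C@@H](CO)O1`; the difference between the two cores is not broken down here. In this assay compound 3 is again given only as a limit, > 200000 nM, because the limit of > 200000 nM in this assay, at which 1 of the 3 values shown sits, is as far as the assay goes.

Compound 4, which has the structure `O=c1nc2oc(CCCCCCCCCI)cc2cn1[C@H]1C[C@H](O)[C@@H](CO)O1` and has not yet been tested, carries the same kind of change as compound 2, namely (iodo in place of bromo on a saturated chain carbon, nine bonds along the chain from an aromatic carbon); here the place is nine bonds along the chain from an aromatic carbon rather than from a triple-bonded carbon. With compound 3 resting at the limit of > 200000 nM in this assay, at which 1 of the 3 values shown sits, the step of a number no higher from compound 3 to compound 4 (the limit leaves the size open) is expected to be small or unreadable. Compound 4 is therefore estimated at 200000 nM, with a range from 100000 nM to 400000 nM.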

Compound 4, minimum cytotoxic concentration: 50000 nM
For compound 4 the middle estimate is 4.0-fold (0.60 log units) above the measured one; the whole stated range lies above it.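

On the second core, iodo in place of bromo on a saturated chain carbon, nine bonds along the chain from an aromatic carbon, gives in this assay an at least 4.0-fold lower number from compound 3 to compound 4 (0.60 log units; beyond the scatter). Set beside the same exchange on the first core, the two steps do not agree: the same change on two cores in this assay, a number no lower (the limit leaves the size open) from compound 1 to compound 2 and an at least 4.0-fold lower number (0.60 log units; beyond the scatter) from compound 3 to compound 4, at least 4.0-fold (0.60 log units) apart, beyond the scatter of two such steps. This shows that in this pair of cores the exchange does not carry over with the same outcome, but the step on the first core cannot be read in size, the step on the second is only a lower bound, and a single pair per core cannot show whether the gap would hold for other members of the series.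

The compounds shown leave open whether chloro or fluoro at the chain end would follow iodo or bromo on either core. They also leave open how a shorter or longer chain, or an amine or carboxylic acid at its end, would read in this assay.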